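The source may hold more compounds than are shown below. What is called first, only, known or untested is meant among the compounds shown, and "the series" means these compounds.

Working notes on the series.

The shared core of compound 1 `CCn1c(=O)c2nc(-c3cccc(S(=O)(=O)NCCN(C)C)c3)[nH]c2n(CC)c1=O` and compound 2 `CCn1c(=O)c2nc(-c3ccc(S(=O)(=O)N4CCSCC4)cc3)[nH]c2n(CC)c1=O` is held constant; the two differ only in the sulfonyl substituent and its arrangement on the phenyl ring. In an assay for binding affinity to adenosine receptor A1 (Rattus norvegicus), read by radioligand binding (a higher number here means a weaker inhibitor, a lower number a stronger inhibitor), compound 1 gives 553 nM. In this assay compound 2 gives 646 nM, the higher of the two numbers, though the gap to compound 1 lies within the scatter, so no order between them can be read.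

Compound 3 `CCn1c(=O)c2nc(-c3ccc(S(=O)(=O)NCCN(C)C)cc3)[nH]c2n(CC)c1=O` is not yet measured in this assay. It derives from compound 2 by one change: (2-(dimethylamino)ethyl)amino in place of thiomorpholin-4-yl on a sulfonyl sulfur. For the measured compounds named here, no step between two measured compounds isolates this exchange, so its effect has to be guessed from the two values at hand. Both measured compounds sit close together, and the group that enters compound 3 is the same sulfamoyl substituent that compound 1 already carries at 553 nM. The step from compound 2 to compound 3 is therefore expected to be small, with no direction beyond the scatter, a 1.1-fold lower number from compound 2 to compound 3 (0.03 log units; within the scatter). Compound 3 is estimated at 600 nM in this assay, within a range from 250 nM to 1400 nM.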

Compound 3, half-maximal inhibitory concentration: 116 nM
Compound 3: the middle estimate sits 5.2-fold (0.71 log units) above what was measured; measured number below the stated range.
By their numbers in this assay, from the lowest: compound 3; then compounds 1 and 2 (each within the scatter of the next).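

For the compounds shown here, on a sulfonyl sulfur, the exchange of thiomorpholin-4-yl for (2-(dimethylamino)ethyl)amino gives the first step that lies beyond the scatter in this assay: a 5.6-fold lower number from compound 2 to compound 3 (0.75 log units; beyond the scatter). The entering group does not set the number by itself: compound 1 carries the same group with a different arrangement on the phenyl ring and gives 553 nM, while compound 3 gives 116 nM. Going by these compounds alone, the gain seen with this group therefore appears only in the arrangement of compound 3, the one it shares with compound 2, so the exchange and the arrangement on the ring have to be read together. Nothing at hand accounts for the step.

The compounds shown leave open which part of the entering group goes with the lower number: the open chain, the sulfonamide hydrogen or the terminal dimethylamino group. A piperazin-1-yl ring on the sulfonyl sulfur, a longer chain ending in the same dimethylamino group, or a chain ending in a hydroxyl group in place of that amine would begin to separate these parts.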